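The source may hold more compounds than are shown below. What is called first, only, known or untested is meant among the compounds shown, and "the series" means these compounds.

Among the compounds with values here, compound 1 `C/C(=N\OCc1ccncc1)c1ccc(Sc2cc(F)cc(C3CCOCC3)c2)cc1` is one of two compounds measured in a functional assay (blood) for inhibition, with Homo sapiens as the target; on this read-out higher numbers stand for weaker inhibition and lower numbers for stronger inhibition. In this assay compound 1 gives 300 nM, the highest of the two numbers. The other, compound 2 `Fc1cc(Sc2ccc3c(c2)CC/C3=N\OCc2ccncc2)cc(C2CCOCC2)c1`, gives 90 nM in this assay, a lower number lying beyond the usual scatter. The two structures differ in more than one place, so the numbers alone cannot say which part of the difference accounts for the gap.

Compound 3 `C/C(=N\OCC(=O)O)c1ccc(Sc2cc(F)cc(C3CCOCC3)c2)cc1` has not yet been measured. It differs from compound 1 in a single place: carboxy in place of pyridin-4-yl on a saturated chain carbon bound to an oxygen. Within the data shown here, no measured pair shows this change, so nothing in the numbers gathered so far sets its size or direction. The expectation is a modest step toward weaker inhibition, a 2.0-fold higher number from compound 1 to compound 3 (0.30 log units; within the scatter), though a step in either direction, or none beyond the scatter, remains possible. For compound 3 the estimate in this assay is 600 nM, with an expected range from 150 nM to 2500 nM.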

Compound 3, half-maximal inhibitory concentration: 740 nM
Estimate against measurement, compound 3: 1.2-fold (0.09 log units) below; low and high end bracket the measured number.
By their numbers in this assay, from the lowest: compound 2; then compound 1; then compound 3.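

In this assay, carboxy in place of pyridin-4-yl on a saturated chain carbon bound to an oxygen gives a 2.5-fold higher number from compound 1 to compound 3 (0.39 log units; beyond the scatter), so this one swap moves the read-out beyond the usual scatter, though only modestly. Within the data shown here, this is the first view of this place on its own: between these two compounds pyridin-4-yl gives the lower number, yet compound 3, with no ring here and fewer heavy atoms in the entering group, still gives a measurable inhibitory concentration, so the ring is not required for a read-out in this range. Nothing measured here accounts for the size or direction of this step.

A single swap removes the ring and brings in carboxy at once, so the contribution of each remains unresolved; a methyl ester, a primary amide, a phenyl ring or a longer chain ending in a carboxylic acid at this place would help separate them. Also open, on these data alone, is whether the same swap on the core of compound 2 would give a step of similar size.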